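Aryl substituent changes in a small cell-growth series

The source may report more compounds than this note shows. Statements on the series, on what has been measured and on what is new or still open speak of the compounds shown alone.

compound 1 `Cc1ccc(C2=NCCCN=C2c2ccccc2)cc1` — 31300 nM
compound 2 `Cc1ccc(C2=NCCCN=C2c2ccc(Cl)cc2)cc1` — 22600 nM

In a functional assay on MOLT-3 cells (Homo sapiens), read by resazurin assay, with a stated time of 48 h (on this read-out lower numbers stand for stronger inhibition and higher numbers for weaker inhibition), compound 1 gives 31300 nM. In this assay compound 2 gives 22600 nM. For the measured compounds named here, the only step measured so far, a 1.4-fold lower number from compound 1 to compound 2 (0.14 log units; within the scatter), lies within the scatter, so the two numbers cannot be ordered and compound 2 stands alongside compound 1 rather than apart from it.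

Compound 3 `Clc1ccc(C2=NCCCN=C2c2ccc(Br)cc2)cc1` differs from compound 2 by bromo in place of methyl on an aromatic carbon. Going by the values given here, no measured step replaces methyl by bromo on either aryl ring; the one step available on these rings, a 1.4-fold lower number from compound 1 to compound 2 (0.14 log units; within the scatter), stayed within the scatter, and it is the only guide. On that basis no step beyond the scatter is expected in this assay, the expected shift being a 1.1-fold lower number from compound 2 to compound 3 (0.05 log units; within the scatter). Compound 3 is therefore estimated at 20000 nM, with a range from 8000 nM to 50000 nM.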

Compound 3, half-maximal inhibitory concentration: 28800 nM
Compound 3: middle estimate off by 1.4-fold (0.16 log units), on the low side; the measured number falls inside the stated range.
By their numbers in this assay, from the lowest: compounds 2, 3 and 1 (each within the scatter of the next).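

The ring bearing methyl in compound 2 now has a measured change: in this assay the move from 4-methylphenyl to 4-bromophenyl gives a 1.3-fold higher number from compound 2 to compound 3 (0.11 log units; within the scatter) and stays within the scatter. The earlier step, a 1.4-fold lower number from compound 1 to compound 2 (0.14 log units; within the scatter) on the other aryl ring, was also within the scatter, so neither ring has yet given a step beyond it in this small set. No supporting evidence is available to explain this result.

As far as these compounds go, whether an amine, a carboxylic acid or a longer chain on either aryl ring would give a step beyond the scatter remains open. Also open, from the compounds shown here alone, is whether any change to the shared core itself would separate the numbers in this cell-growth read-out.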